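Chloro on the Phenyl Group of Compound 2

The source may report more compounds than this note shows. Statements on the series, on what has been measured and on what is new or still open speak of the compounds shown alone.

Compound 1 `CC1CCN(c2nc(-c3ccccc3)nc3ccc(Br)cc23)CC1`: 57.8%
Compound 2 `Brc1ccc2nc(-c3ccccc3)nc(N3CCC(c4ccccc4)CC3)c2c1`: 57.6%
Compound 3 `Ic1ccc2nc(-c3ccccc3)nc(N3CCC(c4ccccc4)CC3)c2c1`: 82.5%

In a functional assay on the whole organism for inhibition, with Rattus norvegicus as the target, read by paw edema, with stated times of 4 days, 1 h and 2 h, at a dose of 100 mg/kg by the oral route (on this read-out higher numbers stand for more inhibition at the one dose given (going by the name of the read-out) and lower numbers for less inhibition), compound 2 gives 57.6%, the lowest of the three numbers. The closest neighbour is compound 1, since the step of a number 0.2 percentage points lower from compound 1 to compound 2 (within the scatter) lies within the scatter. Compound 3 stands furthest away, reached by a number 24.9 percentage points higher from compound 2 to compound 3 (beyond the scatter).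

Compound 4 `Clc1ccc(-c2nc(N3CCC(c4ccccc4)CC3)c3cc(Br)ccc3n2)cc1` differs from compound 2 in one place: chloro in place of hydrogen on an aromatic carbon. For the measured compounds named here, neither measured step touches the phenyl group, so no step speaks directly to this change. One measured step is within the scatter and the other modest, so no step beyond the scatter is expected here: a number 0.4 percentage points higher from compound 2 to compound 4 (within the scatter). Compound 4 is therefore estimated at 58%, in the range 42% to 74%.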

Compound 4, a percentage reported as inhibition, in the whole organism at one dose (the size of the read-out at that dose, not a potency): 50%
For compound 4 the middle estimate is 8 percentage points above the measured one, and the stated range covers the measured number.
By their numbers in this assay, from the lowest: compounds 4, 2 and 1 (each within the scatter of the next); then compound 3.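

In this assay, for the compounds shown here, the step of a number 7.6 percentage points lower from compound 2 to compound 4 (within the scatter) touches the phenyl group that the earlier steps left untouched, and it shows that 4-chlorophenyl in place of phenyl, with chloro para to a large group, gives no change that can be read. This place thus differs from the iodo in place of bromo step, which went beyond the scatter. Nothing available gives a reason for this result. From the compounds shown here alone, whether a methoxy group or a carboxylic acid in place of chloro would behave alike stays open, as does whether iodo in place of bromo would raise the number with 4-chlorophenyl present.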